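A few compounds are considered here, and "the series" means these few. Any claim that something is new, unique, unknown or untested is made for them only; others in the source may bear on it.

Compound 1, with the structure `CC(=O)Nc1ccc(O)c(C(=O)/C=C/c2cccc(F)c2)c1`, is examined in an ADME assay on MT4 cells (Homo sapiens) for cytotoxicity, read by MTT assay, with a stated time of 4 days (a higher number here means that more compound is tolerated, a lower number that less compound is tolerated), and gives 30100 nM. Compound 2, with the structure `CC(=O)Nc1ccc(O)c(C(=O)/C=C/c2cccc(C(F)(F)F)c2)c1`, carries the change trifluoromethyl in place of fluoro on an aromatic carbon relative to compound 1; in this assay compound 2 gives 32100 nM, and the step of a 1.1-fold higher number from compound 1 to compound 2 (0.03 log units; within the scatter) is within the usual scatter. Compound 3, with the structure `CC(=O)Nc1ccc2oc(-c3ccc(F)cc3)cc(=O)c2c1`, has a different core; how its core differs from that of compound 1 is not broken down here. In this assay compound 3 gives 203000 nM, the highest of the three numbers, standing beyond the scatter from both compound 1 and compound 2.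

Compound 4, with the structure `CC(=O)Nc1ccc2oc(-c3ccc(C(F)(F)F)cc3)cc(=O)c2c1`, is not yet measured. It differs from compound 3 by trifluoromethyl in place of fluoro on an aromatic carbon. Going by the values given here, this is the same kind of change as the one from compound 1 to compound 2, though the surroundings differ: in compound 2 the new group sits meta to a large group, in compound 4 para to a large group. Because the earlier step of a 1.1-fold higher number from compound 1 to compound 2 (0.03 log units; within the scatter) was small, the step of a 1.0-fold higher number from compound 3 to compound 4 (0.01 log units; within the scatter) is expected to be small as well. The estimate for compound 4 in this assay is therefore 210000 nM, expected to fall between 100000 nM and 420000 nM.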

Compound 4, half-maximal cytotoxic concentration: 330000 nM
Estimate against measurement, compound 4: 1.6-fold (0.20 log units) below; the measured number falls inside the stated range.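

In this assay, trifluoromethyl in place of fluoro on an aromatic carbon of the core of compound 3 gives a 1.6-fold higher number from compound 3 to compound 4 (0.21 log units; within the scatter), so this swap leaves the number within the scatter on this core too. Set beside the earlier step, the change carries over from one core to the other without a difference that can be told apart: the same change on two cores in this assay, a 1.1-fold higher number (0.03 log units; within the scatter) from compound 1 to compound 2 and a 1.6-fold higher number (0.21 log units; within the scatter) from compound 3 to compound 4, 1.5-fold (0.18 log units) apart, within the scatter of two such steps. Going by these compounds alone, this shows only that the swap was tolerated alike in these two pairs; two pairs establish no rule for the series, and since the group also sits in different surroundings on the two cores, they cannot separate the influence of the core from that of the group's place.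

The compounds shown leave open whether a group of another kind at this place, such as an amine or a carboxylic acid, would shift the number on either core. They also leave open whether a longer chain in place of the acetyl group would do so.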